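The source may hold more compounds than are shown below. What is called first, only, known or untested is meant among the compounds shown, and "the series" means these compounds.

Compounds measured so far:
- Compound 1 `Nc1nc(N)c2cc(CSC(=S)N3CCN(C4CCCCC4)CC3)ccc2n1`: 6800 nM
- Compound 2 `CC(=O)c1ccc(N2CCN(C(=S)SCc3ccc4nc(N)nc(N)c4c3)CC2)cc1`: 2490 nM

In a functional assay on MCF7 cells (Homo sapiens) for antiproliferative activity, read by MTT assay, with a stated time of 72 h (a lower number here means a stronger inhibitor, a higher number a weaker inhibitor), compound 2 gives the lower of the two numbers, 2490 nM. Compound 3 `Nc1nc(N)c2cc(CSC(=S)N3CCN(c4ncccn4)CC3)ccc2n1` has not yet been measured. It differs from compound 2 as follows: pyrimidin-2-yl in place of 4-acetylphenyl on an amine nitrogen in a ring. In words, pyrimidin-2-yl stands in place of 4-acetylphenyl on an amine nitrogen in a ring.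

Among the compounds with values here, one measured step bears on this, at the same place: a 2.7-fold lower number from compound 1 to compound 2 (0.44 log units; beyond the scatter), a modest change on going from cyclohexyl to 4-acetylphenyl. Within the data shown here, no measured compound carries pyrimidin-2-yl, so the direction is uncertain. Among the measured compounds shown here, a step of similar modest size or smaller is expected, leaning towards a higher number, since compound 2 holds the lowest value so far. The estimate is a 1.5-fold higher number from compound 2 to compound 3 (0.18 log units; within the scatter) in this assay. For compound 3 the estimated value is 3800 nM, with an expected range of 1400 nM to 10000 nM.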

Compound 3, half-maximal inhibitory concentration: 4190 nM
Beside the measured number, compound 3's estimate is 1.1-fold (0.04 log units) below it; the measured number falls inside the stated range.
By their numbers in this assay, from the lowest: compounds 2, 3 and 1 (each within the scatter of the next, the first and the last beyond it).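

With pyrimidin-2-yl on this amine nitrogen in a ring, the number in this assay cannot be separated from that of either earlier group: the change shows a 1.7-fold higher number from compound 2 to compound 3 (0.23 log units; within the scatter), and the other comparison shows a 1.6-fold lower number from compound 1 to compound 3 (0.21 log units; within the scatter). The earlier pair showed only that exchanging cyclohexyl for 4-acetylphenyl gives a step beyond the scatter, whereas compound 3 shows that a smaller aromatic ring with 2 hetero atoms at this place gives a value that cannot be told apart from either end of that step. No measurement shown here accounts for this result.

The compounds shown leave open whether the acetyl group contributes to the value of compound 2, a question that a plain phenyl on the same nitrogen would address. They also leave open whether an open-chain amine or a carboxylic acid at this place would give a step beyond the scatter.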